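The source may hold more compounds than are shown below. What is called first, only, known or untested is meant among the compounds shown, and "the series" means these compounds.

Compound 3 `COc1ccc(C(=O)C2Sc3nnc(-c4cc(OC)c(OC)c(OC)c4)n3NC2c2ccco2)cc1` carries a 4-methoxyphenyl on its carbonyl carbon. In a functional assay on MCF7 cells (Homo sapiens) for cytotoxicity, read by MTT assay, with a stated time of 48 h (on this read-out lower numbers stand for stronger inhibition and higher numbers for weaker inhibition), compound 3 reaches only the assay's limit, > 100000 nM, not a number. Compound 2 `COc1cc(-c2nnc3n2NC(c2ccco2)C(C(=O)C2CC2)S3)cc(OC)c1OC`, with a cyclopropyl at that place, likewise stops at the limit, > 100000 nM. Compound 1 `COc1cc(-c2nnc3n2NC(c2ccco2)C(C(=O)c2ccccc2C)S3)cc(OC)c1OC`, with a 2-methylphenyl there, gives 69900 nM. The steps of an at least 1.4-fold higher number from compound 1 to compound 2 (0.15 log units; that floor lies within the scatter) and an at least 1.4-fold higher number from compound 1 to compound 3 (0.15 log units; that floor lies within the scatter) are thus only floors, and the step that the two limits leave unreadable from compound 2 to compound 3 cannot be read, given (the limit of > 100000 nM in this assay, at which 2 of the 3 values shown sit). Compound 4 `COc1cccc(C(=O)C2Sc3nnc(-c4cc(OC)c(OC)c(OC)c4)n3NC2c2ccco2)c1` differs from compound 3 in one respect: 3-methoxyphenyl in place of 4-methoxyphenyl on a carbonyl carbon. For the measured compounds named here, no measured step moves a methoxy around a ring, so no change beyond the scatter is expected, an estimated step of a number no higher from compound 3 to compound 4 (the limit leaves the size open). Compound 4 is therefore estimated at 100000 nM, between 50000 nM and 300000 nM, most probably again only a limit.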

Compound 4, half-maximal inhibitory concentration: > 100000 nM
Compound 4 gave a limit, no number; the forecaster's own chance of this, stated with the estimate: 70%; the middle value sits exactly at the limit.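

In this assay, 3-methoxyphenyl in place of 4-methoxyphenyl on the carbonyl carbon yields no number, as compound 4 also stops at a limit, > 100000 nM. For the compounds shown here, the steps linking compound 4 to compound 2 and compound 3 cannot be read, because both ends of each are limits: the limit of > 100000 nM in this assay, at which 3 of the 4 values shown sit. Compound 1, with its 2-methylphenyl, remains the only compound here with a number, and the one readable step, an at least 1.4-fold higher number from compound 1 to compound 4 (0.15 log units; that floor lies within the scatter), is only a floor.

As far as these compounds go, whether the two methoxyphenyl groups differ at all remains unknown. Also open, from the compounds shown here alone, is whether another group at this place, such as a phenyl carrying an amine or a carboxylic acid, would give a clearly lower number.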